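From propargylamino to ethyl on the shared core

The source may hold more compounds than are shown below. What is called first, only, known or untested is meant among the compounds shown, and "the series" means these compounds.

Measured in an ADME assay on HeLa cells (Homo sapiens) for cytotoxicity, read by LDH release, with a stated time of 24 h; on this read-out lower numbers stand for stronger inhibition and higher numbers for weaker inhibition:
- compound 1 `COCCOCCOCCOCc1ccc2c(Br)cc(Br)c(O)c2n1`: 100000 nM
- compound 2 `C#CCNCc1ccc2c(Br)cc(Br)c(O)c2n1`: > 25000 nM, a limit and not a number

Compound 2 sits at the limit of > 25000 nM in this assay, at which 1 of the 2 values shown sits, so its position is bounded and no exact number is available. Compound 3 `CCCc1ccc2c(Br)cc(Br)c(O)c2n1` keeps the shared core and carries ethyl in place of propargylamino on a saturated chain carbon bound to an aromatic carbon. Among the measured compounds shown here, no measured step between compounds is available as a guide. The expectation in this assay rests on compound 1 at 100000 nM, so a read-out at the weak end of the scale is expected again, with no clear direction. The expected change is small, and the estimate means a step that the limit leaves unreadable from compound 2 to compound 3. A report as a limit alone is also quite possible. Compound 3 is estimated at 40000 nM, with an expected range of 15000 nM to 100000 nM.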

Compound 3, half-maximal inhibitory concentration: > 50000 nM
Compound 3: no number, only a limit; the forecaster's own chance of this, stated with the estimate: 55%; at least 1.2-fold (0.09 log units) between middle value and limit.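

Among the compounds shown here, compound 2 and compound 3 are both reported only as limits and not as numbers, so no step between them can be read in this assay. The compounds shown leave open whether ethyl in place of propargylamino changes this read-out at all, and in which direction.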